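Dropping the Chloro Group from Compound 1

A few compounds are considered here, and "the series" means these few. Any claim that something is new, unique, unknown or untested is made for them only; others in the source may bear on it.

Compound 1 `O=S(=O)(NCCCNCc1ccc(Cl)cc1)c1cc(C(F)(F)F)cc(C(F)(F)F)c1` gives 2800 nM in a functional assay on MIA PaCa-2 cells (Homo sapiens) for inhibition, read by MTT assay, with a stated time of 72 h; a higher number here means a weaker inhibitor of growth, a lower number a stronger inhibitor of growth.
Compound 2 `CC(C)c1ccc(S(=O)(=O)NCCCCCCNCc2ccc(Br)cc2)cc1` gives 5730 nM in this assay.
Compound 3 `O=S(=O)(NCCCCCCNCc1ccc(Br)cc1)c1ccc(C(F)(F)F)cc1` gives 3830 nM in this assay.

Among these three, compound 1 gives the lowest number; compound 3 sits within the scatter of it, while compound 2 lies beyond. Compound 4 `O=S(=O)(NCCCNCc1ccccc1)c1cc(C(F)(F)F)cc(C(F)(F)F)c1` differs from compound 1 by hydrogen in place of chloro on an aromatic carbon. For the measured compounds named here, the only measured step, a 1.5-fold lower number from compound 2 to compound 3 (0.17 log units; within the scatter), concerns a different change on an aromatic carbon and does not test loss of chloro; no measured pair does. Going by the values given here, with no direct precedent, the step is expected to be small and toward a higher number, a 1.6-fold higher number from compound 1 to compound 4 (0.21 log units; within the scatter). Compound 4 is therefore expected to give about 4500 nM in this assay, with a range from 2000 nM to 10000 nM.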

Compound 4, concentration for 50% growth inhibition: 11000 nM
Compound 4: the middle estimate sits 2.4-fold (0.39 log units) below what was measured, and the stated range ends below it.
By their numbers in this assay, from the lowest: compounds 1, 3, 2 and 4 (each within the scatter of the next, the first and the last beyond it).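

In this assay, for the compounds shown here, the change of 4-chlorobenzyl to benzyl gives a 3.9-fold higher number from compound 1 to compound 4 (0.59 log units; beyond the scatter), the first measured step at this position and one that lies beyond the scatter. Unlike the earlier step between compound 2 and compound 3, which stayed within the scatter, it shows that the number responds to what sits on this aromatic carbon. Nothing available accounts for the size of this step.

From the compounds shown here alone, it remains open whether fluoro or methoxy on this carbon would give a number closer to that of compound 1 or of compound 4. Going by these compounds, whether the same step would hold on a longer chain also remains open.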